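Replacing cyclohexyl with 2-fluorophenyl on an amine nitrogen

A few compounds are considered here, and "the series" means these few. Any claim that something is new, unique, unknown or untested is made for them only; others in the source may bear on it.

Compound 1 `Nc1ccccc1NC(=O)c1ccc(CSC(=S)N2CCN(C3CCCCC3)CC2)cc1` gives 30.6% in a functional assay on HeLa cells (Homo sapiens) for antiproliferative activity, read by CCK-8 assay, with a stated time of 72 h, tested at 2 uM; on this read-out higher numbers stand for a stronger effect at the one concentration tested and lower numbers for a weaker effect; it stands at the top of the two numbers recorded, yet the gap to compound 2 `CN(Cc1ccncc1)C(=S)SCc1ccc(C(=O)Nc2ccccc2N)cc1`, which gives 29.5% in this assay, lies within the scatter, so the two are not distinguishable. Among the compounds with values here, no single-change step between measured compounds is available. Compound 3 `Nc1ccccc1NC(=O)c1ccc(CSC(=S)N2CCN(c3ccccc3F)CC2)cc1` differs from compound 1 by 2-fluorophenyl in place of cyclohexyl on an amine nitrogen in a ring. Nothing measured here shows how this change acts, so the expected step is a number 1.4 percentage points higher from compound 1 to compound 3 (within the scatter), within the scatter and with no direction favoured. Compound 3 is estimated at 32%, within 18% to 48%.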

Compound 3, a percentage reported as inhibition, at one concentration (the size of the read-out at that concentration, not a potency): 17.5%
The estimate for compound 3 lay 14.5 percentage points above the measured number, and the stated range ends above it.
By their numbers in this assay, from the lowest: compound 3; then compounds 2 and 1 (each within the scatter of the next).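

In this assay, within the data shown here, the amine nitrogen in the ring proves sensitive to its substituent: 2-fluorophenyl in place of cyclohexyl gives a number 13.1 percentage points lower from compound 1 to compound 3 (beyond the scatter) and this is the first single-change step. The step describes the effect at the one concentration tested and is not a potency change. Nothing available bears on why the number falls. Still open, going by these compounds, is whether the fall goes with the aromatic ring or with the fluorine, which an unsubstituted phenyl on the same nitrogen would separate. A methyl there would test whether a ring is needed at all.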